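This account rests on a few compounds, and the source may have more. Where it says the series, first, only, none or still open, it means among the compounds named here.

Values measured so far in a physicochemical assay for lipophilicity, read by HPLC, measured as octanol-water partition; a lower number here means a more polar compound, a higher number a more lipophilic compound
- compound 1 (`N#Cc1c(-c2ccco2)[n+]([O-])c2ccc(C3OCCO3)cc2[n+]1[O-]`): 2
- compound 2 (`O=C(N/N=C/c1ccc2no[n+]([O-])c2c1)c1ccccc1`): 2.2
- compound 3 (`NC(=O)c1c(COc2ccc(/C=N/NC(=O)c3ccncc3)cc2)no[n+]1[O-]`): 1.3

Compound 2 (2.2) lies within the scatter of compound 1 (2). Compound 3 (1.3) stands lower than compound 2, and that gap lies beyond the scatter. The next compound to be read is compound 4 (`Nc1ccc(C(=O)N/N=C/c2ccc3no[n+]([O-])c3c2)cc1`). It departs from compound 2 in one place, with amino in place of hydrogen on an aromatic carbon, para to a large group (amino in place of hydrogen on an aromatic carbon). The same difference reads as phenyl to 4-aminophenyl.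

Within the data shown here, no two measured compounds differ in only one place, so the series offers no direct measured step for this change, and the expectation rests on the structural change alone. An estimated fall beyond the scatter is expected in this assay (a number 0.70 log units lower from compound 2 to compound 4 (beyond the scatter)). Compound 4 is expected at 1.5 (estimated range 1 to 2).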

Compound 4, partition coefficient: 1.2
The estimate for compound 4 lay 0.30 log units above the measured number; measured number inside the range.
By their numbers in this assay, from the lowest: compounds 4 and 3 (each within the scatter of the next); then compounds 1 and 2 (each within the scatter of the next).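

In this assay, the series now has its first step between compounds that differ in one place: amino in place of hydrogen on an aromatic carbon, para to a large group, gives a number 1.00 log units lower from compound 2 to compound 4 (beyond the scatter). Among these compounds, the earlier compounds offered no such pair, so this is the first sign that this position on the phenyl of compound 2 can shift the number beyond the scatter with a single added amino group. Nothing measured here accounts for the size of the step.

One step at one position leaves open whether a different group on the same carbon, such as hydroxyl, methoxy or dimethylamino, would shift the number as far. From the compounds shown here alone, it is also open whether the same change from phenyl to 4-aminophenyl would give a similar step on another core.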